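Curcumin-like piperidinone series: cytotoxicity on L02 cells

The compounds below may be only part of what the source reports. "The series", "measured", "known", "first", "only" and "open" are said of these compounds alone.

Measured compounds:
compound 1 `CN1C/C(=C\c2cccnc2)C(=O)/C(=C/c2ccccc2C(F)(F)F)C1` 14100 nM
compound 2 `CN1C/C(=C\c2ccncc2)C(=O)/C(=C/c2ccc(F)cc2Br)C1` 12400 nM
compound 3 `CN1C/C(=C\c2ccncc2)C(=O)/C(=C/c2ccccc2C(F)(F)F)C1` 15800 nM

All three measured compounds were run in an ADME assay on L02 cells (Homo sapiens) for cytotoxicity, read by MTT assay, with a stated time of 24 h; a lower number here means a stronger inhibitor, a higher number a weaker inhibitor. Compound 1 stands second highest of the three numbers; its nearest neighbour is compound 3, and its furthest is compound 2, and both of those gaps are within the scatter. For the measured compounds named here, the one step between compounds differing in a single place is a 1.1-fold higher number from compound 1 to compound 3 (0.05 log units; within the scatter), so the pyridinyl swap changes nothing beyond the scatter.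

Compound 4 `N#Cc1ccc(S(=O)(=O)N2C/C(=C\c3cccnc3)C(=O)/C(=C/c3ccccc3C(F)(F)F)C2)cc1` has not yet been measured in this assay. It differs from compound 1 by (4-cyanophenyl)sulfonyl in place of methyl on an amine nitrogen in a ring. Going by the values given here, no measured step touches the amine nitrogen in the ring: the only step available concerns the pyridinyl group, and compound 2 differs from the others at two places at once. There is therefore no basis in these data for expecting a step in either direction in this assay for compound 4 beyond the scatter, and the group that enters is far larger than the group that leaves, which widens the uncertainty.

For compound 4 the number in this assay is estimated at 14000 nM, with a range from 4500 nM to 45000 nM. The step this estimate means for compound 4 is expected to be a 1.0-fold lower number from compound 1 to compound 4 (0.00 log units; within the scatter).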

Compound 4, half-maximal inhibitory concentration: 13200 nM
For compound 4 the middle estimate is 1.1-fold (0.03 log units) above the measured one; measured number inside the range.
By their numbers in this assay, from the lowest: compounds 2, 4, 1 and 3 (each within the scatter of the next).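

For the compounds shown here, compound 4 gives the first reading at the amine nitrogen in the ring, a place where the earlier compounds all carry methyl. In this assay, (4-cyanophenyl)sulfonyl in place of methyl gives a step (a 1.1-fold lower number from compound 1 to compound 4 (0.03 log units; within the scatter)), so on this single pair a group of 11 heavy atoms, with a six-membered aromatic ring and 3 hydrogen-bond acceptors, leaves the number where methyl had it, even though the change in size far exceeds that of the pyridinyl swap (a 1.1-fold higher number from compound 1 to compound 3 (0.05 log units; within the scatter)). Nothing available here bears on why the number stays put.

The compounds shown leave open whether the same holds with the rest of the molecule changed, for example whether this change on the core of compound 3 or compound 2 also stays within the scatter. They also leave open how other groups on the same nitrogen would read, such as a bare hydrogen, an acetyl, a benzyl or a chain ending in a carboxylic acid, and whether a plain phenylsulfonyl without the nitrile reads like (4-cyanophenyl)sulfonyl.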